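Swapping trifluoromethyl for 1H-pyrazol-1-yl: working notes

The source may hold more compounds than are shown below. What is called first, only, known or untested is meant among the compounds shown, and "the series" means these compounds.

Measured so far in a functional assay on SW-620 cells (Homo sapiens) for cytotoxicity, read by MTT assay, with stated times of 4 h and 72 h, tested at 2 uM; on this read-out higher numbers stand for weaker inhibition and lower numbers for stronger inhibition
- compound 1 `COc1ccc(/C=C/C(=O)c2ccc(Nc3cc(C)nc4nc(SCc5nc6ccccc6[nH]5)nn34)cc2)cc1` gives 170 nM
- compound 2 `Cc1cc(Nc2ccc(C(=O)/C=C/c3ccccc3)cc2)n2nc(SCc3nc4ccccc4[nH]3)nc2n1` gives 130 nM
- compound 3 `Cc1cc(Nc2ccc(C(=O)/C=C/c3ccc(C(F)(F)F)cc3)cc2)n2nc(SCc3nc4ccccc4[nH]3)nc2n1` gives 1850 nM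

Compound 3 has the highest number of the three and is the weakest inhibitor here. The next compound to be measured is compound 4 `Cc1cc(Nc2ccc(C(=O)/C=C/c3ccc(-n4cccn4)cc3)cc2)n2nc(SCc3nc4ccccc4[nH]3)nc2n1`, with 1H-pyrazol-1-yl in place of trifluoromethyl on an aromatic carbon, para to a large group (1H-pyrazol-1-yl in place of trifluoromethyl on an aromatic carbon).

For the measured compounds named here, three measured steps concern this same place. The step of a 14-fold higher number from compound 2 to compound 3 (1.15 log units; beyond the scatter) and the step of an 11-fold higher number from compound 1 to compound 3 (1.04 log units; beyond the scatter) are both large, and both arrive at trifluoromethyl. The step of a 1.3-fold lower number from compound 1 to compound 2 (0.12 log units; within the scatter) stays within the scatter. Going by the values given here, no measured compound carries a ring at this place, so only part of the large gap is expected to close in this assay. The expected change is a 4.1-fold lower number from compound 3 to compound 4 (0.61 log units; beyond the scatter), towards a lower number. For compound 4 the estimated value is 450 nM, with an expected range of 120 nM to 1700 nM.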

Compound 4, half-maximal inhibitory concentration: 340 nM
Estimate against measurement, compound 4: 1.3-fold (0.12 log units) above; the measured number falls inside the stated range.
By their numbers in this assay, from the lowest: compounds 2, 1 and 4 (each within the scatter of the next, the first and the last beyond it); then compound 3.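

In this assay, the large loss seen with trifluoromethyl does not extend to a ring at this place on the aromatic carbon, since the change gives a 5.4-fold lower number from compound 3 to compound 4 (0.74 log units; beyond the scatter). The ring does not recover everything, with a 2.6-fold higher number from compound 2 to compound 4 (0.42 log units; beyond the scatter), while against methoxy there is no separation, with a 2.0-fold higher number from compound 1 to compound 4 (0.30 log units; within the scatter). No evidence is available on why 1H-pyrazol-1-yl and trifluoromethyl differ here.

Open, from the compounds shown here alone, is whether trifluoromethyl stands alone or whether other groups, such as chloro, an amine or a carboxylic acid, also give numbers as high as compound 3. Also open, going by these compounds, is whether the ring nitrogens of 1H-pyrazol-1-yl matter, which a plain phenyl or an imidazol-1-yl group at the same place would address.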